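A few compounds are considered here, and "the series" means these few. Any claim that something is new, unique, unknown or untested is made for them only; others in the source may bear on it.

In an assay on membranes from brain for binding affinity to adenosine receptor A1 (Rattus norvegicus), read by radioligand binding, tested at 20 uM (on this read-out higher numbers stand for more inhibition at the one concentration tested (going by the name of the read-out) and lower numbers for less inhibition), compound 3 `Cn1c(=O)[nH]c2c(cnn2-c2ccc(F)cc2)c1=N` gives 26%, the lowest of the three numbers recorded. Its nearest neighbour is compound 1 `Cn1c(=O)[nH]c2c(cnn2-c2ccc(Br)cc2)c1=N`, which in this assay gives 34%; the furthest is compound 2 `Cn1c(=O)[nH]c2c(cnn2-c2cccc(Br)c2)c1=N`, which gives 40%. Among the measured compounds shown here, the one single-place step among the measured compounds runs between compound 1 and compound 3: a number 8 percentage points lower from compound 1 to compound 3 (within the scatter), a change of fluoro in place of bromo on an aromatic carbon that left the read-out essentially where it was. Compound 2 and compound 3 differ in more than one place, so only their two values can be set side by side.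

Compound 4 `Cn1c(=O)[nH]c2c(cnn2-c2ccccc2)c1=N` differs from compound 3 by hydrogen in place of fluoro on an aromatic carbon. For the measured compounds named here, the only step that bears on this change is the halogen swap on the same aromatic carbon, and that step stayed within the scatter. A further reduction of the substituent to hydrogen is therefore expected to move the number little, and the expected step of a number 2 percentage points lower from compound 3 to compound 4 (within the scatter) is taken as none beyond the scatter. Compound 4 is expected to give about 24%, with a range from 10% to 40%.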

Compound 4, a percentage reported as inhibition, at one concentration (the size of the read-out at that concentration, not a potency): 30%
Compound 4: the middle estimate sits 6 percentage points below what was measured; low and high end bracket the measured number.
By their numbers in this assay, from the lowest: compounds 3, 4, 1 and 2 (each within the scatter of the next, the first and the last beyond it).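

In this assay, taking the halogen off altogether changes no more than swapping one halogen for another: fluoro gives way to hydrogen with a number 4 percentage points higher from compound 3 to compound 4 (within the scatter). Hydrogen in place of bromo likewise stays inside the usual scatter, with a number 4 percentage points lower from compound 1 to compound 4 (within the scatter) and with a number 10 percentage points lower from compound 2 to compound 4 (within the scatter), so on this aromatic carbon, para to a large group, hydrogen, fluoro and bromo cannot be told apart on this read-out. Nothing measured here offers a reason for these numbers.

The compounds shown carry only hydrogen and halogens on this ring, so it remains open whether any group at this place can move the number beyond the scatter. An amine, a carboxylic acid or a methoxy group could answer that, and each would put something other than a halogen on this carbon.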